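The source may report more compounds than this note shows. Statements on the series, on what has been measured and on what is new or still open speak of the compounds shown alone.

In a functional assay on A-375 cells (Homo sapiens) for inhibition, read by MTT assay, with a stated time of 120 h (a lower number here means a stronger inhibitor, a higher number a weaker inhibitor), compound 1 `CNC(=O)/C=C/c1ccc(NC(=O)Nc2ccc(Cl)c(C(F)(F)F)c2)cc1` gives 20900 nM. Compound 3 `CC(NC(=O)/C=C/Oc1ccc(NC(=O)Nc2cc(C(F)(F)F)ccc2Cl)cc1)c1ccccc1` gives 16000 nM, which lies within the scatter of the value of compound 1. For compound 2 `CC1CN(C(=O)/C=C/c2ccc(NC(=O)Nc3ccc(Cl)c(C(F)(F)F)c3)cc2)CC(C)O1` the assay reports no number, only a limit, > 50000 nM, and this is the limit of > 50000 nM in this assay, at which 1 of the 3 values shown sits.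

The next compound to be tested is compound 4 `CNC(=O)/C=C(\C)c1ccc(NC(=O)Nc2ccc(Cl)c(C(F)(F)F)c2)cc1`, which carries a 1-methyl-2-(methylcarbamoyl)ethenyl in place of the 2-(methylcarbamoyl)ethenyl of compound 1 on an aromatic carbon: 1-methyl-2-(methylcarbamoyl)ethenyl in place of 2-(methylcarbamoyl)ethenyl on an aromatic carbon. Within the data shown here, only one measured step offers any guide. Among the measured compounds shown here, with 2,6-dimethylmorpholin-4-yl in place of methylamino on a carbonyl carbon, it gives an at least 2.3-fold higher number from compound 1 to compound 2 (0.37 log units; beyond the scatter), but it changes a different place from the one at issue for compound 4, so it is only a loose guide. The change in compound 4 is small by the counts given, and no step beyond the scatter is expected in this assay, with perhaps a slight drift toward a higher number. The expected step is a 1.2-fold higher number from compound 1 to compound 4 (0.08 log units; within the scatter). For compound 4 the estimated value is 25000 nM, with an expected range from 10000 nM to 50000 nM.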

Compound 4, half-maximal inhibitory concentration: > 50000 nM
Compound 4 ended at the assay's limit; the forecaster's own chance of this, stated with the estimate: 20%; middle value at least 2.0-fold (0.30 log units) from the limit.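

Replacing 2-(methylcarbamoyl)ethenyl with 1-methyl-2-(methylcarbamoyl)ethenyl, on an aromatic carbon para to a large group, gives an at least 2.3-fold higher number from compound 1 to compound 4 (0.37 log units; beyond the scatter) in this assay. Among these compounds, this shows that the position, which no earlier step had touched, is not indifferent to change, even though the group only grows from 6 to 7 heavy atoms and its hydrogen-bond donor and acceptor counts stay the same. For compound 4 the result, > 50000 nM, is a limit and not a number, and it is the limit already reached when compound 1 took 2,6-dimethylmorpholin-4-yl in place of methylamino, so changes at two different places on compound 1 now end in the same spot: the limit of > 50000 nM in this assay, at which 2 of the 4 values shown sit.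

The true size of the step and any ordering of compounds 2 and 4 stay unknown, since both rest on a limit, and one methyl is the only substituent shown on this ethenyl chain. As far as these compounds go, whether a fluorine or an ethyl on the same carbon, or a saturated chain in place of the ethenyl, would keep the value of compound 1 or also reach the limit remains open.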